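The compounds below may be only part of what the source reports. "The series", "measured", "known", "first", "only" and "open" are said of these compounds alone.

Working notes on a small urea series sharing one core. Compound 1 `Cc1cccc(NC(=O)Nc2cccc(CNc3ncnc4ccccc34)c2)c1` is measured in a functional assay on A549 cells (Homo sapiens) for antiproliferative activity, read by MTT assay (a higher number here means a weaker inhibitor, a lower number a stronger inhibitor), and compound 1 gives 30200 nM. Compound 2 `O=C(Nc1cccc(CNc2ncnc3ccccc23)c1)Nc1ccccc1F` gives 26100 nM. Compound 3 `COc1cc2ncnc(NCc3cccc(NC(=O)Nc4cccc(C)c4)c3)c2cc1OC` carries a different core from compound 1 but the same 3-methylphenyl urea; in this assay compound 3 gives 27100 nM. All three numbers lie within the scatter of one another: compound 3 sits nearest to compound 2 and furthest from compound 1, yet neither gap separates it from the others, so the three compounds cannot be told apart on these data.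

Among the compounds with values here, the one single-point step available is the exchange of the aryl group on the urea nitrogen between compound 1 and compound 2, a 1.2-fold lower number from compound 1 to compound 2 (0.06 log units; within the scatter). Compound 4 `COc1cc2ncnc(NCc3cccc(NC(=O)Nc4ccc([N+](=O)[O-])cc4)c3)c2cc1OC` differs from compound 3 by 4-nitrophenyl in place of 3-methylphenyl on an amide-type nitrogen. Within the data shown here, this is the same kind of exchange, an aryl group on the amide-type nitrogen, and the one precedent moved nothing beyond the scatter; no data on a nitro group exist. Compound 4 is therefore expected to stay close to compound 3, with a step of a 1.0-fold lower number from compound 3 to compound 4 (0.00 log units; within the scatter). Compound 4 is estimated at 27000 nM, with a range from 12000 nM to 60000 nM.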

Compound 4, half-maximal inhibitory concentration: > 50000 nM
Compound 4 was reported as a limit (the forecaster's own chance of this, stated with the estimate: 10%); middle value at least 1.8-fold (0.26 log units) away from the limit.
By their numbers in this assay, from the lowest: compounds 2, 3 and 1 (each within the scatter of the next). At a limit, above all of these: compound 4.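

In this assay, the change to 4-nitrophenyl on the amide-type nitrogen gives an at least 1.8-fold higher number from compound 3 to compound 4 (0.26 log units; that floor lies within the scatter). Unlike the exchange from compound 1 to compound 2, this step has only a floor and no measured size, so the aryl group at this position is no longer shown to be without effect, though nothing here separates compound 4 from compound 3 beyond the scatter. Compound 4 is the only compound in the series reported as a limit, not as a number, and this is what sets it apart from the closely grouped values of compounds 1, 2 and 3: the limit of > 50000 nM in this assay, at which 1 of the 4 values shown sits.

As far as these compounds go, the true value of compound 4 remains unknown, and with it whether the exchange from 3-methylphenyl to 4-nitrophenyl moves the number beyond the scatter at all, or whether 4-nitrophenyl would give a similar reading on the core of compound 1. Also open, from the compounds shown here alone, is whether a phenyl group carrying an amine or a carboxylic acid on the same amide-type nitrogen would read like compound 3 or reach the limit like compound 4.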